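A few compounds are considered here, and "the series" means these few. Any claim that something is new, unique, unknown or untested is made for them only; others in the source may bear on it.

Measured compounds:
compound 1, `CCC1C(=O)N(C)c2cnc(Nc3ccc(S(=O)(=O)NCC(C)C)cc3)nc2N1c1ccn(C)n1`, which gives 8350 nM;
compound 2, `CCCCNS(=O)(=O)c1ccc(Nc2ncc3c(n2)N(c2ccn(C)n2)C(CC)C(=O)N3C)cc1`, which gives 5780 nM;
compound 3, `CCCCNC(=O)c1ccc2c(ccn2-c2ncc3c(n2)N(C2CCCC2)[C@H](CC)C(=O)N3C)c1`, which gives 634 nM.

All three values come from a functional assay on MCF7 cells (Homo sapiens) for antiproliferative activity, read by CCK-8 assay, with a stated time of 72 h; a lower number here means a stronger inhibitor of growth, a higher number a weaker inhibitor of growth. Compound 2 and compound 1 share a core and differ in one place, by isopropyl in place of propyl on a saturated chain carbon bound to a sulfonamide nitrogen. This change moves the number by a 1.4-fold higher number from compound 2 to compound 1 (0.16 log units; within the scatter), so the two compounds cannot be told apart in this assay.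

Compound 3 has a different core from compound 2; the difference between the two cores is not broken down here. What the two values show is that compound 3 gives the lowest number of the three, with compound 2 and compound 1 both well beyond the scatter above it.

Compound 4, `CC[C@@H]1C(=O)N(C)c2cnc(-n3ccc4cc(C(=O)NCC(C)C)ccc43)nc2N1C1CCCC1`, has not yet been measured. It differs from compound 3 by isopropyl in place of propyl on a saturated chain carbon bound to an amide-type nitrogen. The place is not the same as in the earlier pair: there the branching carbon is bound to a sulfonamide nitrogen, here to an amide-type nitrogen, so this is the same kind of change, not the same change.

Given that the earlier step, a 1.4-fold higher number from compound 2 to compound 1 (0.16 log units; within the scatter), stayed within the scatter, compound 4 is expected to sit close to compound 3, with an expected step of a 1.3-fold higher number from compound 3 to compound 4 (0.13 log units; within the scatter). The estimate for compound 4 in this assay is 850 nM, expected to fall between 350 nM and 2000 nM.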

Compound 4, concentration for 50% growth inhibition: 953 nM
Beside the measured number, compound 4's estimate is 1.1-fold (0.05 log units) below it, within the range that was stated.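

In this assay, isobutyl in place of butyl on the amide-type nitrogen gives a 1.5-fold higher number from compound 3 to compound 4 (0.18 log units; within the scatter), so compound 3 and compound 4 cannot be told apart. Set beside the matching change on the sulfonamide nitrogen, the step reads the same on both cores: the same change on two cores in this assay, a 1.4-fold higher number (0.16 log units; within the scatter) from compound 2 to compound 1 and a 1.5-fold higher number (0.18 log units; within the scatter) from compound 3 to compound 4, 1.0-fold (0.02 log units) apart, within the scatter of two such steps This shows that, on these two cores and in this one assay, the branched chain and the straight chain give values that cannot be separated, but it rests on only two pairs and does not show that the same would hold on any other core in the series, nor does it explain why the steps agree.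

Among these compounds, since both steps stay within the scatter, they show only that this particular change made no measurable difference, and they leave open whether any other group at this place would do so: a longer chain such as hexyl, a small ring such as cyclopropylmethyl, or a chain ending in an amine or a carboxylic acid. Also open, from the compounds shown here alone, is whether such groups would behave alike on the sulfonamide and the amide-type nitrogen, as butyl and isobutyl do here.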